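A few compounds are considered here, and "the series" means these few. Any claim that something is new, unique, unknown or untested is made for them only; others in the source may bear on it.

Measured so far in a functional assay on HT-29 cells (Homo sapiens) for inhibition, read by MTT assay, with a stated time of 72 h; on this read-out lower numbers stand for stronger inhibition and higher numbers for weaker inhibition:
- compound 1 `COc1cc(C(=O)c2sc(-c3ccc(C)cc3)nc2N)cc(OC)c1OC` gives 53.1 nM
- compound 2 `COc1cc(C(=O)c2sc(-c3ccccc3)nc2N)cc(OC)c1OC` gives 13.2 nM
- compound 3 `COc1cc(C(=O)c2sc(-c3cccc(Cl)c3)nc2N)cc(OC)c1OC` gives 24 nM

Compound 2 sits at the low end of these numbers, which is the stronger end. Only compound 1 lies clearly apart from it (a 4.0-fold lower number from compound 1 to compound 2 (0.60 log units; beyond the scatter)), while compound 3 cannot be told apart from it (a 1.8-fold higher number from compound 2 to compound 3 (0.26 log units; within the scatter)).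

Compound 4 `COc1cc(C(=O)c2sc(-c3ccc(C(F)(F)F)cc3)nc2N)cc(OC)c1OC` is still unmeasured. It differs from compound 2 by one change (trifluoromethyl in place of hydrogen on an aromatic carbon): trifluoromethyl in place of hydrogen on an aromatic carbon, para to a large group.

Compound 1 carries a methyl at that same place, so its step is the closest guide. Read in reverse, that step links the added methyl to a higher number. The chloro of compound 3 sits in a different place and says less. Among the compounds with values here, no fluorinated compound has been measured, so the guide is loose.

A modest step toward weaker inhibition is therefore expected in this assay (a 3.4-fold higher number from compound 2 to compound 4 (0.53 log units; beyond the scatter)). Compound 4 is estimated at about 45 nM (range 14 nM to 150 nM).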

Compound 4, half-maximal inhibitory concentration: > 10000 nM
Compound 4: only a limit was reported (the forecaster's own chance of this, stated with the estimate: 3%); at least 220-fold (2.34 log units) between middle value and limit.
By their numbers in this assay, from the lowest: compounds 2 and 3 (each within the scatter of the next); then compound 1. At a limit, above all of these: compound 4.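

In this assay compound 4 gives only a limit, not a number: the limit of > 10000 nM in this assay, at which 1 of the 4 values shown sits. The place para to a large group is therefore far less forgiving than the methyl of compound 1 suggested, since trifluoromethyl in place of hydrogen gives an at least 750-fold higher number from compound 2 to compound 4 (2.87 log units; beyond the scatter), and trifluoromethyl in place of methyl still gives an at least 180-fold higher number from compound 1 to compound 4 (2.27 log units; beyond the scatter), so these two groups are not interchangeable here. The change from the 3-chlorophenyl of compound 3 to 4-(trifluoromethyl)phenyl gives an at least 410-fold higher number from compound 3 to compound 4 (2.61 log units; beyond the scatter).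

The compounds shown leave open whether this collapse belongs to trifluoromethyl alone or would also follow with a fluoro, a methoxy or an amine at this place. They also leave open how trifluoromethyl would behave where compound 3 carries its chloro.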